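Amide change from compound 1 to compound 4

A few compounds are considered here, and "the series" means these few. Any claim that something is new, unique, unknown or untested is made for them only; others in the source may bear on it.

Compound 1 `O=C1C=CC(=O)C(c2cc(-c3ccc(C(=O)N4CCCCC4)s3)on2)=C1` is measured in a functional assay on A549 cells (Homo sapiens) for cytotoxicity, read by XTT assay, with a stated time of 72 h; a lower number here means a stronger inhibitor, a higher number a weaker inhibitor. The value of compound 1 in this assay, > 30000 nM, is a limit of the assay and not a number. Compound 2 `COc1ccc(OC)c(-c2cc(-c3ccc(C(=O)N4CCCCC4)s3)on2)c1` also sits at a limit in this assay, > 30000 nM. Compound 3 `COc1ccc(OC)c(-c2cc(-c3ccc(C(=O)N4CCC(C(F)(F)F)CC4)s3)on2)c1` likewise gives only a limit in this assay, > 30000 nM. Going by the values given here, the single measured step, a step that the two limits leave unreadable from compound 2 to compound 3, is trifluoromethyl in place of hydrogen on a saturated ring carbon, and its size cannot be read because of the limit of > 30000 nM in this assay, at which 3 of the 3 values shown sit.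

Compound 4 `CN(C)C(=O)c1ccc(-c2cc(C3=CC(=O)C=CC3=O)no2)s1` has not yet been measured in this assay. Compared with compound 1, the difference is dimethylamino in place of piperidin-1-yl on a carbonyl carbon. Among the compounds with values here, no measured step touches the group on the carbonyl carbon, and the one step that exists, on a saturated ring carbon in the other pair, is unreadable, so there is no measured basis for a direction. The step from compound 1 to compound 4 in this assay is therefore expected to be a step that the limit leaves unreadable from compound 1 to compound 4, that is, none that the assay can show. Compound 4 is estimated to give 40000 nM in this assay, within 10000 nM to 150000 nM, most likely reported only as a limit again.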

Compound 4, half-maximal inhibitory concentration: > 30000 nM
Compound 4 ended at the assay's limit (the forecaster's own chance of this, stated with the estimate: 80%); the middle value lies beyond the limit too.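

In this assay compound 4 gives > 30000 nM and this is a limit, not a number. No new step can be read between compound 1 and compound 4, because both stand at that limit: the limit of > 30000 nM in this assay, at which 4 of the 4 values shown sit. The compounds shown leave open whether any change to the amide or the shared core gives a readable value in this assay at all.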